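The compounds below may be only part of what the source reports. "The series", "measured", "known", "first", "only" and "open" are said of these compounds alone.

Of the compounds shown here, two built on a shared core have been tested in a functional assay on MDA-MB-231 cells (Homo sapiens) for cytotoxicity, read by MTT assay, with a stated time of 72 h; a lower number here means a stronger inhibitor, a higher number a weaker inhibitor. Among the compounds with values here, compound 2 `COc1ccc(Cn2nc(-c3ccccc3)c3cc(C(=N)Nc4ccccc4)nc(NC4CCCCC4)c32)cc1` gives 3400 nM and is the only compound of the pair with an actual number in this assay. From the compounds shown here alone, compound 1 `COc1ccc(Cn2nc(-c3ccccc3)c3cc(C(=N)Nc4cccc(C(F)(F)F)c4)nc(Nc4cc(OC)c(OC)c(OC)c4)c32)cc1` reaches only the limit of the assay, > 50000 nM, which is a boundary rather than a measured value, so its true potency stays unknown. Compound 3 `COc1ccc(Cn2nc(-c3ccccc3)c3cc(C(=N)Nc4ccccc4)nc(Nc4cc(OC)c(OC)c(OC)c4)c32)cc1` has not yet been measured. It differs from compound 2 in one place: 3,4,5-trimethoxyphenyl in place of cyclohexyl on a nitrogen on an aromatic ring. Within the data shown here, no measured pair differs in exactly this way, so there is no directly comparable step; compound 1 and compound 2 differ in more than this one place, and all that can be said is that compound 1 sits at the assay limit (the limit of > 50000 nM in this assay, at which 1 of the 2 values shown sits). The expected change in this assay is a loss of potency beyond the usual scatter, a 4.4-fold higher number from compound 2 to compound 3 (0.64 log units; beyond the scatter). Compound 3 is therefore estimated at 15000 nM, within a range from 4000 nM to 50000 nM.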

Compound 3, half-maximal inhibitory concentration: 42100 nM
Compound 3: the middle estimate sits 2.8-fold (0.45 log units) below what was measured; low and high end bracket the measured number.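

In this assay this place, a nitrogen on an aromatic ring, now has a direct one-change comparison: 3,4,5-trimethoxyphenyl in place of cyclohexyl gives a 12-fold higher number from compound 2 to compound 3 (1.09 log units; beyond the scatter) and so a large loss of potency. The value of compound 1 remains a limit of the assay and not a number: the limit of > 50000 nM in this assay, at which 1 of the 3 values shown sits. Hydrogen in place of trifluoromethyl on an aromatic carbon gives an at least 1.1-fold lower number from compound 1 to compound 3 (0.07 log units; that floor lies within the scatter) and that floor lies within the scatter, so the effect of this change stays unsettled.

Still open is whether the loss comes with the aromatic ring itself or with its methoxy groups: a plain phenyl on this nitrogen is not among the compounds shown. Also open, from the compounds shown here alone, is how a smaller ring such as cyclopentyl, or an open chain such as butyl, would fare at this place.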